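The source may hold more compounds than are shown below. What is called first, only, known or untested is meant among the compounds shown, and "the series" means these compounds.

Compound 1 `O=C(CN1CCC(c2cccc[n+]2[O-])CC1)Nc1ccc(F)cc1F`: 103 nM
Compound 2 `O=C(CN1CCC(c2cccc[n+]2[O-])CC1)Nc1ccccc1F`: 270 nM

Among the compounds with values here, in a functional assay on HEK293 cells for agonist activity at D(4) dopamine receptor (Homo sapiens), read by FLIPR (on this read-out higher numbers stand for an effect only at larger amounts of compound and lower numbers for an effect already at smaller amounts), compound 2 has the higher of the two numbers measured so far, and compound 1 has the lower one, 103 nM. Compound 3 `Cc1cc(F)ccc1NC(=O)CN1CCC(c2cccc[n+]2[O-])CC1` arises from compound 2 through the change (4-fluoro-2-methylphenyl in place of 2-fluorophenyl on an amide-type nitrogen). Within the data shown here, one measured step bears on this: a 2.6-fold higher number from compound 1 to compound 2 (0.42 log units; beyond the scatter), which took one fluorine away. Compound 3 brings a fluorine back into that ring while exchanging the remaining fluoro for methyl, so the number is expected to move back toward that of compound 1, giving a 1.8-fold lower number from compound 2 to compound 3 (0.26 log units; within the scatter). Compound 3 is therefore estimated at 150 nM, with a range from 50 nM to 450 nM.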

Compound 3, half-maximal effective concentration: 60 nM
Estimate against measurement, compound 3: 2.5-fold (0.40 log units) above, and the stated range covers the measured number.
By their numbers in this assay, from the lowest: compounds 3 and 1 (each within the scatter of the next); then compound 2.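

The change to 4-fluoro-2-methylphenyl on the amide-type nitrogen gives a 4.5-fold lower number from compound 2 to compound 3 (0.65 log units; beyond the scatter), so this position tolerates a methyl on the ring and the number does not rise. Methyl in place of fluoro gives a 1.7-fold lower number from compound 1 to compound 3 (0.23 log units; within the scatter), which means these two groups cannot be told apart on this read-out. No measurement here gives a reason for either step. From the compounds shown here alone, it remains open how a ring carrying methyl without the fluoro would behave. Chloro or methoxy in place of that methyl also remains untested among the compounds shown.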